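Swapping a Methyl for Trifluoromethoxy on the Sulfonyl Ring

The source may hold more compounds than are shown below. What is called first, only, known or untested is meant among the compounds shown, and "the series" means these compounds.

Of the compounds shown here, two sharing one core have been tested in a functional assay on MDA-MB-231 cells (Homo sapiens) for inhibition, read by sulforhodamine B assay, tested at 10 uM; a lower number here means less inhibition, a higher number more inhibition at the concentration tested (going by the name of the read-out). Compound 1 `CN1CCN(c2ccc(C3=NN(C(=O)c4ccc(F)cc4)C(c4ccc(N(C)C)cc4)C3)cc2)CC1` gives 3.5%. Among the measured compounds shown here, compound 2 `Cc1ccc(S(=O)(=O)N2N=C(c3ccc(N4CCN(C)CC4)cc3)CC2c2ccc(N(C)C)cc2)cc1` gives 10.7%, the higher of the two numbers, although the only measured step, a number 7.2 percentage points higher from compound 1 to compound 2 (within the scatter), lies within the scatter of the method. Compound 3 `CN1CCN(c2ccc(C3=NN(S(=O)(=O)c4ccc(OC(F)(F)F)cc4)C(c4ccc(N(C)C)cc4)C3)cc2)CC1` is the untested compound; it differs from compound 2 by trifluoromethoxy in place of methyl on an aromatic carbon. For the measured compounds named here, no measured step touches that position: the single step from compound 1 to compound 2 exchanged the whole group on the ring nitrogen rather than a substituent on its aromatic ring, so it gives no guide to how this change will read. With nothing pointing either way, the expected change is small, a number 1.3 percentage points higher from compound 2 to compound 3 (within the scatter), and not beyond the scatter. Compound 3 is therefore estimated at 12%, with a range from 0% to 30%.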

Compound 3, a percentage reported as inhibition, at one concentration (the size of the read-out at that concentration, not a potency): 10.6%
The estimate for compound 3 lay 1.4 percentage points above the measured number; the range from low to high includes it.
By their numbers in this assay, from the lowest: compounds 1, 3 and 2 (each within the scatter of the next).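

Among the compounds shown here, this is the first measured change on the aromatic ring carried by the sulfonyl group: going from 4-methylphenyl to 4-(trifluoromethoxy)phenyl in this assay gives a number 0.1 percentage points lower from compound 2 to compound 3 (within the scatter), so the two compounds cannot be told apart. Trifluoromethoxy brings five heavy atoms where methyl has one, yet this larger group, para to a large group, produces no step beyond the scatter at the one concentration tested. Nothing available explains why the number holds steady at this position.

Going by these compounds, it remains open whether any group at this place can move the number beyond the scatter, for example an amine, a carboxylic acid or a nitrile. A single concentration also leaves open how compound 2 and compound 3 would compare at other concentrations.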